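Ethyl to Isopropyl on the Longer Linker: Compound 4

The source may hold more compounds than are shown below. What is called first, only, known or untested is meant among the compounds shown, and "the series" means these compounds.

Of the compounds shown here, three built on one shared core have so far been tested in an assay on isolated protein for inhibition of advanced glycosylation end product-specific receptor (Homo sapiens), read by FRET, with stated times of 30 min and 1 h, tested at 4 uM; a lower number here means less inhibition, a higher number more inhibition at the concentration tested (going by the name of the read-out). Compound 1 `CCN1CCC(Oc2ccc(-c3nc4ccc(Oc5ccc(Cl)cc5)cc4o3)cc2)CC1` gives 15.3% in this assay. Compound 2 `CC(C)N1CCC(Oc2ccc(-c3nc4ccc(Oc5ccc(Cl)cc5)cc4o3)cc2)CC1` gives 12.7%. Compound 3 `CCN1CCC(COc2ccc(-c3nc4ccc(Oc5ccc(Cl)cc5)cc4o3)cc2)CC1` gives 2.1%, the lowest of the three numbers, and it stands there beyond the scatter: the steps of a number 13.2 percentage points lower from compound 1 to compound 3 (beyond the scatter) and a number 10.6 percentage points lower from compound 2 to compound 3 (beyond the scatter) both set it apart from the other two.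

Compound 4 `CC(C)N1CCC(COc2ccc(-c3nc4ccc(Oc5ccc(Cl)cc5)cc4o3)cc2)CC1` has not yet been measured. It differs from compound 3 in one place: methyl in place of hydrogen on a saturated chain carbon bound to an amine nitrogen in a ring and a saturated chain carbon. Read one bond further out, the change is ethyl to isopropyl on the piperidine nitrogen, while the (1-ethylpiperidin-4-yl)methyl linker to the aromatic oxygen stays.

Among the measured compounds shown here, one measured step bears directly on this change, since it is the same hydrogen-to-methyl exchange on the shorter linker: a number 2.6 percentage points lower from compound 1 to compound 2 (within the scatter). That step stayed within the scatter, so no step beyond the scatter is expected here either; the estimate is a number 1.1 percentage points lower from compound 3 to compound 4 (within the scatter). Because compound 3 already sits at 2.1%, compound 4 is expected to give about 1%, within a range of -8% to 10%.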

Compound 4, a percentage reported as inhibition, at one concentration (the size of the read-out at that concentration, not a potency): 26.2%
For compound 4 the middle estimate is 25.2 percentage points below the measured one; measured number outside the range, above it.
By their numbers in this assay, from the lowest: compound 3; then compounds 2 and 1 (each within the scatter of the next); then compound 4.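

In this assay, methyl in place of hydrogen on a saturated chain carbon bound to an amine nitrogen in a ring and a saturated chain carbon gives a number 24.1 percentage points higher from compound 3 to compound 4 (beyond the scatter). The effect of this methyl depends on the linker, so the step on the shorter linker could not be carried over to the longer one: the same change on two cores in this assay, a number 2.6 percentage points lower (within the scatter) from compound 1 to compound 2 and a number 24.1 percentage points higher (beyond the scatter) from compound 3 to compound 4, 26.7 percentage points apart, beyond the scatter of two such steps The linker change also depends on the group at the far end of the piperidine: with isopropyl, (1-isopropylpiperidin-4-yl)methyl in place of 1-isopropylpiperidin-4-yl gives a number 13.5 percentage points higher from compound 2 to compound 4 (beyond the scatter), whereas the matching change with ethyl gives a number 13.2 percentage points lower from compound 1 to compound 3 (beyond the scatter). Changing both places at once gives a number 10.9 percentage points higher from compound 1 to compound 4 (beyond the scatter), which leaves compound 4 with the highest number of the four and shows that the isopropyl group and the longer linker have to be read together, not as two separate contributions.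

As far as these compounds go, it remains open whether a third methyl on the same carbon, giving tert-butyl, or a cyclopropyl group in place of the isopropyl would raise the number further on this linker, and whether a longer chain between the piperidine and the aromatic oxygen would keep it. These numbers come from a single concentration, so they leave the potency of compound 4 open as well.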